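This account rests on a few compounds, and the source may have more. Where it says the series, first, only, none or still open, it means among the compounds named here.

The measured compounds and their values in a functional assay on BMMC cells (Mus musculus, strain C57BL/6) for inhibition, with stated times of 5 days and 48 h; a higher number here means a weaker inhibitor, a lower number a stronger inhibitor:
Compound 1, `C=C1CC[C@@H]2[C@](C)(CNCc3cccc(OC)c3)[C@H](O)CC[C@@]2(C)[C@@H]1/C=C/C1=CCOC1=O`: 780 nM
Compound 2, `C=C1CC[C@@H]2[C@](C)(CNCc3ccc(OC)c(OC)c3)[C@H](O)CC[C@@]2(C)[C@@H]1/C=C/C1=CCOC1=O`: 3740 nM
Compound 3, `C=C1CC[C@@H]2[C@](C)(CNCc3ccc(C#N)cc3)[C@H](O)CC[C@@]2(C)[C@@H]1/C=C/C1=CCOC1=O`: 1130 nM

Compound 3 stands second highest of the three numbers. Its nearest neighbour is compound 1, with a 1.4-fold higher number from compound 1 to compound 3 (0.16 log units; within the scatter), a step that stays within the scatter. Its furthest is compound 2, with a 3.3-fold lower number from compound 2 to compound 3 (0.52 log units; beyond the scatter), a modest step beyond the scatter. The remaining measured step, a 4.8-fold higher number from compound 1 to compound 2 (0.68 log units; beyond the scatter), is also modest.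

Compound 4 is `C=C1CC[C@@H]2[C@](C)(CNCc3ccc([N+](=O)[O-])cc3)[C@H](O)CC[C@@]2(C)[C@@H]1/C=C/C1=CCOC1=O`. It differs from compound 3 in one place: nitro in place of cyano on an aromatic carbon. None of the three measured steps exchanges one of these two groups for the other; they all concern methoxy or cyano groups. Those steps were modest at most, and compound 3 with its cyano lay within the scatter of compound 1. For the measured compounds named here, the exchange is therefore expected to move this assay little, with no direction favoured and no step clearly beyond the scatter. Compound 4 is estimated at 1300 nM, with a range from 600 nM to 2800 nM. The expected step, a 1.2-fold higher number from compound 3 to compound 4 (0.06 log units; within the scatter), would stay within the scatter.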

Compound 4, half-maximal inhibitory concentration: 1340 nM
Compound 4: middle estimate off by 1.0-fold (0.01 log units), on the low side; low and high end bracket the measured number.
By their numbers in this assay, from the lowest: compounds 1, 3 and 4 (each within the scatter of the next); then compound 2.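

In this assay, for the compounds shown here, placing nitro instead of cyano on the aromatic carbon para to a large group gives a 1.2-fold higher number from compound 3 to compound 4 (0.07 log units; within the scatter) and so leaves the read-out unchanged within the scatter, which no earlier step could show for this pair of groups. The same holds against the 3-methoxyphenyl group, with a 1.7-fold higher number from compound 1 to compound 4 (0.24 log units; within the scatter) as the step, whereas the 3,4-dimethoxyphenyl group stays apart, with a 2.8-fold lower number from compound 2 to compound 4 (0.45 log units; beyond the scatter) as the step. Nothing given here accounts for why cyano and nitro read alike at this carbon.

The compounds shown leave open whether this tolerance extends to other groups on that carbon, such as an amine or a carboxylic acid. They also leave open how a longer chain between the amine nitrogen and the aromatic ring would read.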